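This account rests on a few compounds, and the source may have more. Where it says the series, first, only, none or still open, it means among the compounds named here.

Values in a functional assay on A2058 cells (Homo sapiens) for antiproliferative activity, read by luminescence and CellTiter-Glo, with a stated time of 96 h; a higher number here means a weaker inhibitor, a lower number a stronger inhibitor:
- compound 1 `COc1ccc(-c2ccc(F)c(C(=O)Nc3c[nH]nc3C(=O)Nc3ccc(F)cc3)c2F)cn1`: "not determined" (no result reported)
- compound 2 `NC(=O)c1ccc(-c2ccc(F)c(C(=O)Nc3c[nH]nc3C(=O)Nc3ccc(F)cc3)c2F)cn1`: 295 nM
- compound 3 `O=C(Nc1ccc(F)cc1)c1n[nH]cc1NC(=O)c1c(F)ccc(-c2cccc(O)c2)c1F`: "not determined" (no result reported)

Compound 1 has no single number to stand on, and compound 3 is in the same position. Among the compounds with values here, only compound 2 gives a number, 295 nM, so the series has no measured step and no rank order yet.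

The next compound is compound 4 `O=C(Nc1ccc(F)cc1)c1n[nH]cc1NC(=O)c1c(F)ccc(-c2ccncc2)c1F`. The structural change is pyridin-4-yl in place of 6-methoxypyridin-3-yl on an aromatic carbon, ortho to a fluoro group, meta to a large group and para to a fluoro group. The core of compound 1 is otherwise kept.

Within the data shown here, no step from compound 1 can be measured, so the only anchor is compound 2 at 295 nM. In this assay, a result for compound 4 is expected to lie no further from that anchor than the scatter, in no favoured direction, though with wide uncertainty. The estimated half-maximal inhibitory concentration of compound 4 is 250 nM, with an expected range of 60 nM to 1000 nM.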

Compound 4, half-maximal inhibitory concentration: 2940 nM
Compound 4: the middle estimate sits 12-fold (1.07 log units) below what was measured; the whole stated range lies below it.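

In this assay, this position now has its first readable step: pyridin-4-yl in place of 6-carbamoylpyridin-3-yl gives a 10-fold higher number from compound 2 to compound 4 (1.00 log units; beyond the scatter). The aromatic carbon ortho to a fluoro group and para to a fluoro group is therefore sensitive to the group it carries, and of the two groups with numbers, 6-carbamoylpyridin-3-yl gives the lower value. Nothing measured here accounts for the size of this step.

Steps involving compound 1 and compound 3 cannot be read, and the one readable step changes both the carbamoyl group and the point of attachment of the pyridine ring, so the contribution of each stays open. A plain pyridin-3-yl group or a 6-aminopyridin-3-yl group on this carbon would help separate the two.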